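Moving the Trifluoromethyl Around the Phenyl Ring

This account rests on a few compounds, and the source may have more. Where it says the series, first, only, none or still open, it means among the compounds named here.

Three measured compounds share one core and differ either in the (trifluoromethyl)phenyl group or in the core itself. In a functional assay on MCF7 cells (Homo sapiens) for inhibition, read by MTT assay, with a stated time of 72 h (on this read-out lower numbers stand for stronger inhibition and higher numbers for weaker inhibition), compound 1 `Cc1nc(N(C)C(=O)NC(=O)c2c(F)cccc2F)sc1C(=O)N/N=C/c1cccc(C(F)(F)F)c1` gives 28.2 ug/mL, compound 2 `Cc1nc(N(C)C(=O)NC(=O)c2c(F)cccc2F)sc1C(=O)N/N=C/c1ccccc1C(F)(F)F` gives 7.34 ug/mL, and compound 3 `CN(C(=O)NC(=O)c1c(F)cccc1F)c1nc(C(F)(F)F)c(C(=O)N/N=C/c2ccccc2C(F)(F)F)s1` gives 20.4 ug/mL. Compound 2 thus stands lowest of the three, with compound 3 nearest and compound 1 furthest. The step of a 3.8-fold lower number from compound 1 to compound 2 (0.58 log units; beyond the scatter) shows that the placement of the trifluoromethyl on the phenyl ring moves the read-out, while the step of a 2.8-fold higher number from compound 2 to compound 3 (0.44 log units; beyond the scatter) alters the core and does not bear on the present change. Compound 4 `Cc1nc(N(C)C(=O)NC(=O)c2c(F)cccc2F)sc1C(=O)N/N=C/c1ccc(C(F)(F)F)cc1` differs from compound 2 by 4-(trifluoromethyl)phenyl in place of 2-(trifluoromethyl)phenyl on a carbon with a double bond to nitrogen. On these data alone, only the first step bears on it, and it shows that the 2-(trifluoromethyl)phenyl arrangement is the lower of the two arrangements tried, while the 4-(trifluoromethyl)phenyl arrangement is untested. A modest rise toward the number of compound 1 is therefore expected. Compound 4 is estimated at 18 ug/mL, within 7 ug/mL to 50 ug/mL, an expected step of a 2.5-fold higher number from compound 2 to compound 4 (0.39 log units; beyond the scatter).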

Compound 4, half-maximal inhibitory concentration: 30.6 ug/mL
Compound 4: middle estimate off by 1.7-fold (0.23 log units), on the low side; measured number inside the range.
By their numbers in this assay, from the lowest: compound 2; then compounds 3, 1 and 4 (each within the scatter of the next).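

In this assay the 4-(trifluoromethyl)phenyl group gives a 4.2-fold higher number from compound 2 to compound 4 (0.62 log units; beyond the scatter) and so sets the 2-(trifluoromethyl)phenyl arrangement apart from both other placements on the phenyl ring, not from one alone. The step of a 1.1-fold higher number from compound 1 to compound 4 (0.04 log units; within the scatter) leaves the 3-(trifluoromethyl)phenyl and 4-(trifluoromethyl)phenyl arrangements indistinguishable on this read-out, so of the three placements only the 2-(trifluoromethyl)phenyl one separates. Nothing measured here accounts for this difference.

On these data alone, it remains open whether the lower number depends on trifluoromethyl itself, which a plain phenyl, a 2-chlorophenyl or a 2-methoxyphenyl group on the same carbon would help to settle. As far as these compounds go, it is also open whether the 3-(trifluoromethyl)phenyl and 4-(trifluoromethyl)phenyl groups would keep the same standing on the core of compound 3.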